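Furan-2-yl in place of 4-methoxyphenyl next to the ring sulfur

The compounds below may be only part of what the source reports. "The series", "measured", "known", "first", "only" and "open" are said of these compounds alone.

Of the compounds shown here, two on a shared core have been measured. Compound 1 `COc1cccc(-c2sc(N)c(C(=O)c3ccc(Cl)cc3)c2CC(C)(C)C)c1` gives in an assay on CHO cells for displacement of a labelled ligand from adenosine receptor A3 (Homo sapiens), read by scintillation counting, tested at 10 uM (on this read-out higher numbers stand for more inhibition at the one concentration tested (going by the name of the read-out) and lower numbers for less inhibition), 1%, and compound 2 `COc1ccc(-c2sc(N)c(C(=O)c3ccc(Cl)cc3)c2CC(C)(C)C)cc1` gives in this assay 2%. Going by the values given here, the only step between them, a number 1 percentage points higher from compound 1 to compound 2 (within the scatter), swaps one methoxyphenyl for another. Compound 2 thus stands highest of the two numbers, with compound 1 nearest and within the scatter of it; both numbers are small.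

Compound 3 `CC(C)(C)Cc1c(-c2ccco2)sc(N)c1C(=O)c1ccc(Cl)cc1` differs from compound 2 in one place: furan-2-yl in place of 4-methoxyphenyl on an aromatic carbon. Among the compounds with values here, no measured step exchanges an aromatic carbon ring for a five-membered ring with one hetero atom here, so the single known step bears only loosely, showing that altering the group at this place left the read-out within the scatter. Compound 3 is therefore expected to show no step beyond the scatter, an estimated a number 3 percentage points higher from compound 2 to compound 3 (within the scatter). Compound 3 is estimated at 5%, within a range from 0% to 20%.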

Compound 3, a percentage reported as inhibition, at one concentration (the size of the read-out at that concentration, not a potency): 1%
For compound 3 the middle estimate is 4 percentage points above the measured one; the measured number falls inside the stated range.
By their numbers in this assay, from the lowest: compounds 1, 3 and 2 (each within the scatter of the next).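

Going by these compounds alone, at the aromatic carbon next to the ring sulfur, the earlier compounds exchanged only one methoxyphenyl for another. Furan-2-yl now puts a five-membered aromatic ring with 1 hetero atom in place of a six-membered aromatic ring of carbon only, and this assay shows a number 1 percentage points lower from compound 2 to compound 3 (within the scatter) and no change at the digits printed from compound 1 to compound 3 (within the scatter) on the same read-out. Across these three compounds, then, neither the kind of aromatic ring nor the smaller group separates the numbers at this place, and all of them stay small; no evidence is at hand to account for this.

As far as these compounds go, whether an amine, a carboxylic acid or a longer chain at this place would give a different number remains open. So does whether changing the neopentyl group or the (4-chlorophenyl)carbonyl group, both shared by all three compounds, would move the read-out at all.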